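This account rests on a few compounds, and the source may have more. Where it says the series, first, only, none or still open, it means among the compounds named here.

In a functional assay on MDA-MB-231 cells (Homo sapiens) for inhibition, read by sulforhodamine B assay, with a stated time of 74 h (on this read-out lower numbers stand for stronger inhibition and higher numbers for weaker inhibition), compound 1 `O=C1C=CC2(C=C1)OCC(=O)N2S(=O)(=O)c1ccc(Cl)cc1` gives 2800 nM. Compound 2 `O=C1C=CC2(C=C1)OCC(=O)N2S(=O)(=O)c1ccc([N+](=O)[O-])cc1` gives > 10000 nM, which is a limit of the assay and not a number. Compound 2 therefore has no exact position in the series. Compound 3 `COc1ccc(S(=O)(=O)N2C(=O)COC23C=CC(=O)C=C3)cc1` follows from compound 2 by methoxy in place of nitro on an aromatic carbon, with methoxy in place of nitro, para to a large group. Among the compounds with values here, only one measured step bears on this change: an at least 3.5-fold higher number from compound 1 to compound 2 (0.55 log units; beyond the scatter), with nitro in place of chloro. Methoxy itself has not been tested. Replacing nitro is expected to reverse that step in direction, at a similar size, giving a lower number in this assay, near compound 1 at 2800 nM. The expected step is an at least 2.5-fold lower number from compound 2 to compound 3 (0.39 log units; beyond the scatter). For compound 3 the estimated value is 4000 nM, with an expected range of 1500 nM to 10000 nM.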

Compound 3, half-maximal inhibitory concentration: > 10000 nM
Compound 3: a limit, no number (the forecaster's own chance of this, stated with the estimate: 25%); at least 2.5-fold (0.39 log units) between middle value and limit.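

In this assay, replacing chloro with methoxy, para to a large group, gives an at least 3.5-fold higher number from compound 1 to compound 3 (0.55 log units; beyond the scatter), so nitro is no longer the only replacement of chloro at this position that moves the number upward. Compound 3 gives > 10000 nM, which is a limit of the assay and not a number. The step from compound 2 to compound 3 cannot be read, so nitro and methoxy cannot be placed in any order: the limit of > 10000 nM in this assay, at which 2 of the 3 values shown sit.

Within the data shown here, compound 1, at 2800 nM, holds the only readable value, so no trend across groups can be drawn from these compounds. From the compounds shown here alone, it remains open whether another group at this position, such as bromo, an amine or a carboxylic acid, would give a readable value at all.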